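The source may report more compounds than this note shows. Statements on the series, on what has been measured and on what is new or still open speak of the compounds shown alone.

Measured so far:
compound 1 `Cc1ccc2c(=O)c(CSC(=S)N3CCCCC3)coc2c1`, 900 nM;
compound 2 `COc1ccc2occ(CSC(=S)N(C(C)C)C(C)C)c(=O)c2c1`, 8900 nM;
compound 3 `Cc1ccc2c(=O)c(CSC(=S)N3CCCC3)coc2c1`, 3600 nM.

In a functional assay on HEp-2 cells (Homo sapiens) for antiproliferative activity, read by MTT assay, with a stated time of 72 h (a higher number here means a weaker inhibitor, a lower number a stronger inhibitor), compound 1 gives the lowest of the three numbers; compound 3 lies nearest, and compound 2 furthest. Going by the values given here, the one step measured in a single place, a 4.0-fold higher number from compound 1 to compound 3 (0.60 log units; beyond the scatter), concerns the amine on the thiocarbonyl carbon, not the aromatic ring. Compound 2 differs from compound 1 in two places at once, so its value shows nothing separable about the ring substituent. Compound 4 `O=c1c(CSC(=S)N2CCCCC2)coc2cc(Cl)ccc12` carries chloro in place of methyl on an aromatic carbon. Among the compounds with values here, no measured step bears on this change, so an account can only expect a step within the scatter, in no fixed direction. Compound 4 is therefore estimated at 1100 nM, between 400 nM and 3500 nM, meaning an expected 1.2-fold higher number from compound 1 to compound 4 (0.09 log units; within the scatter).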

Compound 4, half-maximal inhibitory concentration: 280 nM
Compound 4: middle estimate off by 3.9-fold (0.59 log units), on the high side; measured number below the stated range.
By their numbers in this assay, from the lowest: compound 4; then compound 1; then compound 3; then compound 2.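

In this assay, the aromatic carbon of the shared core turns out to matter: chloro in place of methyl gives a 3.2-fold lower number from compound 1 to compound 4 (0.51 log units; beyond the scatter), the first step measured in a single place on the ring. The number therefore moves with the ring substituent as well as with the amine on the thiocarbonyl carbon. Nothing measured here explains why this step occurs.

From the compounds shown here alone, it remains open how fluoro or bromo on this carbon would compare with chloro. Going by these compounds, it is also open whether chloro would give a similar step alongside a morpholine on the thiocarbonyl carbon.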